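The compounds below may be only part of what the source reports. "The series", "measured", "known", "first", "only" and "open" are said of these compounds alone.

Measured so far:
- compound 1 `O=C(Nc1ccc2c(c1)B(O)OC2)c1cccc(C(F)(F)F)c1`: > 10000 nM
- compound 2 `O=C(Nc1ccc2c(c1)B(O)OC2)c1cccc(C(F)(F)F)c1F`: > 100000 nM

Not yet measured:
- compound 3 `O=C(Nc1ccc2c(c1)B(O)OC2)c1cc(C(F)(F)F)ccc1C(F)(F)F`

In a functional assay on PBMC cells (Homo sapiens) for inhibition, read by HTRF, with stated times of 15 min and 24 h (on this read-out lower numbers stand for stronger inhibition and higher numbers for weaker inhibition), compound 1 gives > 10000 nM, which is a limit and not a number. Compound 2 gives > 100000 nM, also a limit. Compound 1 therefore has no exact position on this scale.

The change to compound 3 is trifluoromethyl in place of hydrogen on an aromatic carbon, ortho to a large group and para to a trifluoromethyl group.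

Going by the values given here, the only measured step that bears on it is a step that the two limits leave unreadable from compound 1 to compound 2, a fluoro for hydrogen replacement whose size cannot be read. It offers no firm size, and neither compound shows measurable inhibition. The expected change is small, if any, and tends towards weaker inhibition: a step that the limit leaves unreadable from compound 1 to compound 3. For compound 3 the estimate is 30000 nM, with an expected range of 8000 nM to 100000 nM.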

Compound 3, half-maximal inhibitory concentration: 2000 nM
Compound 3: middle estimate off by 15-fold (1.18 log units), on the high side, and the stated range ends above it.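

In this assay, trifluoromethyl in place of hydrogen on an aromatic carbon, ortho to a large group and para to a trifluoromethyl group, gives an at least 5.0-fold lower number from compound 1 to compound 3 (0.69 log units; beyond the scatter), so this position can carry a change that registers on this read-out. Compound 3 is the only compound shown whose value is not a limit, and the step from compound 1 to compound 2 cannot be read. The size of the new step is only a minimum because compound 1 stands at a limit: the limit of > 10000 nM in this assay, at which 1 of the 3 values shown sits.

As far as these compounds go, how much larger the true step is remains open. Also open, from the compounds shown here alone, is whether trifluoromethyl is needed at this position, or whether a smaller substituent such as methyl or chloro, or an amine or a carboxylic acid, would give a similar step.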